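The source may hold more compounds than are shown below. What is called first, only, known or untested is meant among the compounds shown, and "the series" means these compounds.

Of the compounds shown here, three have so far been measured in an assay on HEK293 cells with D(4) dopamine receptor (Homo sapiens) as the target, read by FLIPR; a lower number here means a smaller maximal response, a higher number a larger maximal response. Compound 1 `Fc1cccnc1N1CCN(Cc2nc3ccccc3[nH]2)CC1` reaches 27% in this assay, compound 2 `Brc1cc(Br)c2[nH]c(CN3CCN(c4ccccn4)CC3)nc2c1` reaches 37%, and compound 3 `C1=C(c2ccccn2)CCN(Cc2nc3ccccc3[nH]2)C1` reaches 63%. Compound 3 therefore gives the largest maximal response of the three: compound 2 lies nearest, yet its number is lower by an amount beyond the usual scatter, and compound 1 lies furthest, lower by an amount well beyond it. No pair among these three differs in a single place, so no single structural step has yet been measured, and each of them differs from the others in more than one respect.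

Compound 4 `C1=C(c2ccccc2)CCN(Cc2nc3ccccc3[nH]2)C1` differs from compound 3 in one place only: phenyl in place of pyridin-2-yl on a double-bonded ring carbon. For the measured compounds named here, nothing measured here shows what that exchange does to the maximal response, since no other pair of compounds differs in just this way. The expectation for compound 4 is therefore guarded: the step of a number 8 percentage points lower from compound 3 to compound 4 (within the scatter) is expected to be small, possibly within the usual scatter, with a slight lean toward a smaller response. Compound 4 is estimated to reach 55% in this assay, with a plausible range from 30% to 80%.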

Compound 4, largest response reached (reported as efficacy), in percent of the reference or control that the assay uses: 48%
Beside the measured number, compound 4's estimate is 7 percentage points above it, within the range that was stated.
By their numbers in this assay, from the lowest: compounds 1 and 2 (each within the scatter of the next); then compound 4; then compound 3.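

For the compounds shown here, this is the first single-place step: putting phenyl in place of pyridin-2-yl on the double-bonded ring carbon gives a number 15 percentage points lower from compound 3 to compound 4 (beyond the scatter) in this assay. The two groups are alike in size and shape of ring, each with 6 heavy atoms in one six-membered aromatic ring, and they differ only in that a ring nitrogen, counted as one hydrogen-bond acceptor, is replaced by carbon, so this position responds to a change of a single ring atom, although the step is modest and compound 4 keeps a clear maximal response at 48%. Nothing available here gives a measured property that would explain this step.

The compounds shown leave open whether the step reflects the presence of the ring nitrogen in general or something particular to pyridin-2-yl, and one pair cannot say how far the result carries over to other members of the series. Other rings in this place, such as pyrimidinyl or thienyl, or a phenyl carrying a methoxy group or an amine, would be needed to show how the maximal response follows the group at this position.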